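A few compounds are considered here, and "the series" means these few. Any claim that something is new, unique, unknown or untested is made for them only; others in the source may bear on it.

Working notes on the series. Compound 1 `COc1cc2c(cc1OC)C(CC(=O)N(C)C)CC2`, compound 2 `CCN(CC)C(=O)CC1CCc2cc(OC)c(OC)cc21` and compound 3 `CCCCCCNC(=O)CC1CCc2cc(OC)c(OC)cc21` share one core and differ only in the group on a carbonyl carbon. In a functional assay on the whole organism (strain Wistar) for inhibition, with Rattus norvegicus as the target, read by paw edema, with stated times of 60 min and 6 h, at a dose of 100 mg/kg by the oral route (a lower number here means less inhibition, a higher number more inhibition at the dose given (going by the name of the read-out)), compound 1 gives 33.3%, compound 2 gives 31.5% and compound 3 gives 38.3%. Compound 3 thus has the highest of the three numbers, yet the steps to it, a number 5 percentage points higher from compound 1 to compound 3 (within the scatter) and a number 6.8 percentage points higher from compound 2 to compound 3 (within the scatter), are within the scatter, as is a number 1.8 percentage points lower from compound 1 to compound 2 (within the scatter); the three compounds cannot be ranked on these numbers.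

Compound 4 `COc1cc2c(cc1OC)C(CC(=O)N1CCCC1)CC2` is not yet measured. It differs from compound 3 in one place: pyrrolidin-1-yl in place of hexylamino on a carbonyl carbon. Within the data shown here, every measured step so far exchanges one acyclic group on that carbonyl carbon for another, from dimethylamino to diethylamino or to hexylamino, and none of them moved the read-out beyond the scatter. Among the measured compounds shown here, no measured step brings a ring into that position, so the bearing of the known steps is indirect; they only show that the number in this assay stayed level across three different groups at this position.

The expected step of a number 4.3 percentage points lower from compound 3 to compound 4 (within the scatter) is therefore none beyond the scatter. For compound 4 the estimate in this assay is 34%, with a range of 22% to 46%.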

Compound 4, a percentage reported as inhibition, in the whole organism at one dose (the size of the read-out at that dose, not a potency): 22.2%
Estimate against measurement, compound 4: 11.8 percentage points above; the measured number falls inside the stated range.
By their numbers in this assay, from the lowest: compounds 4, 2, 1 and 3 (each within the scatter of the next, the first and the last beyond it).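

In this assay, among these compounds, the entry of a ring on the carbonyl carbon gives the first steps at this position that leave the scatter, with a number 16.1 percentage points lower from compound 3 to compound 4 (beyond the scatter) and a number 11.1 percentage points lower from compound 1 to compound 4 (beyond the scatter) and both of modest size. The number at this position is therefore not level across all the groups shown, although the separation is only partial: the remaining step reads a number 9.3 percentage points lower from compound 2 to compound 4 (within the scatter) and so pyrrolidin-1-yl does not stand apart from every acyclic group in the set. No measured evidence on the reason for this drop is available here.

Among the compounds shown here, whether the ring itself matters or only this particular group remains open, and piperidin-1-yl or morpholin-4-yl on the same carbonyl carbon would test that against pyrrolidin-1-yl. A short chain that keeps the amide hydrogen, such as ethylamino, would also help to separate the loss of that hydrogen from the change in chain length in the step away from hexylamino.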